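This account rests on a few compounds, and the source may have more. Where it says the series, first, only, none or still open, it means among the compounds named here.

Compound 1, `Cc1cc(=O)c2c(O)cc(OCc3ccc(Br)cc3)c([C@H]3CCN(C)C[C@H]3O)c2o1`: 27% in a functional assay on HL-60 cells (Homo sapiens) for inhibition, read by MTT assay, with a stated time of 48 h, tested at 10 uM; on this read-out lower numbers stand for less inhibition of growth and higher numbers for more inhibition of growth at the one concentration tested
Compound 2, `Cc1cc(=O)c2c(O)c(CN3CCCC3)c(O)c([C@H]3CCN(C)C[C@H]3O)c2o1`: 38%
Compound 3, `Cc1oc2c([C@H]3CCN(C)C[C@H]3O)c(O)cc(O)c2c(=O)c1C(O)c1ccc(Cl)cc1`: 2%

Of the compounds shown here, three sharing one core have been measured in this assay, each at a single concentration. Compound 3 stands lowest of the three; its nearest neighbour is compound 1, whose number lies higher by a margin beyond the usual scatter, and compound 2 lies higher still, also beyond the scatter. Compound 3 therefore shows almost no growth inhibition at the concentration used, while compounds 1 and 2 show modest inhibition.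

The unmeasured compound 4, `Cc1oc2c([C@H]3CCN(C)C[C@H]3O)c(O)cc(O)c2c(=O)c1C(O)c1ccc(F)cc1`, is built from compound 3 by a single small change: fluoro in place of chloro on an aromatic carbon. The group sits para to a large group on the ring, and neither the count of heavy atoms, nor donors, acceptors or charge shifts in any meaningful way. Among the measured compounds shown here, no measured pair in this set differs in exactly this way, so there is no directly comparable step to lean on.

With so little altered, and with compound 3 already near the floor of the scale, the expected step is small in this assay, with no direction beyond the scatter: a number 3 percentage points higher from compound 3 to compound 4 (within the scatter). Compound 4 is estimated at 5%, within a range from -5% to 20%.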

Compound 4, percent growth inhibition at one concentration: 30%
The estimate for compound 4 lay 25 percentage points below the measured number, outside the stated range (above it).
By their numbers in this assay, from the lowest: compound 3; then compounds 1, 4 and 2 (each within the scatter of the next, the first and the last beyond it).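

Exchanging chloro for fluoro at this aromatic carbon, para to a large group, is not a silent change: in this assay it gives a number 28 percentage points higher from compound 3 to compound 4 (beyond the scatter). The heavy-atom count, hydrogen-bond donors, hydrogen-bond acceptors and net charge stay the same, yet the result differs by more than the usual scatter, so the near absence of growth inhibition with compound 3 does not belong to the substituted (hydroxy)methyl group as a whole, and with fluoro in place of chloro the group comes with clear inhibition at the one concentration tested. The data shown offer no measurement that explains why these two halogens part ways here.

This single pair gives only two points at this position, so it cannot show whether other groups there, such as methoxy, a nitrile or an amine, would follow fluoro or chloro. It also leaves open whether the step would hold across a range of concentrations, since one concentration says nothing about the full shape of the response.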